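The source may hold more compounds than are shown below. What is called first, only, known or untested is meant among the compounds shown, and "the series" means these compounds.

Measured compounds:
- compound 1 `CN(C)S(=O)(=O)c1ccc(F)c(C#Cc2cc(Cl)ccc2OCC(=O)O)c1`: in a functional assay on cells for antagonist activity at prostaglandin D2 receptor 2 (Homo sapiens), read by flow cytometry, with a stated time of 10 min (on this read-out higher numbers stand for weaker inhibition and lower numbers for stronger inhibition), compound 1 gives 23 nM
- compound 2 `CCCS(=O)(=O)c1ccc(F)c(C#Cc2cc(Cl)ccc2OCC(=O)O)c1`: in this assay compound 2 gives 23 nM
- compound 3 `CC(C)c1ccc(S(C)(=O)=O)cc1C#Cc1cc(Cl)ccc1OCC(=O)O`: in this assay compound 3 gives 360 nM

Compound 3 stands highest of the three numbers, beyond the scatter from both compound 1 and compound 2, which sit together. Within the data shown here, the one step that is measured, no change at the digits printed from compound 1 to compound 2 (within the scatter), exchanges the group on the sulfonyl sulfur and leaves the number unchanged; it therefore says only that the sulfonyl substituent can be varied without effect in this assay.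

Compound 4 `CS(=O)(=O)c1ccc(F)c(C#Cc2cc(Cl)ccc2OCC(=O)O)c1` is not yet measured. The change from compound 3 is fluoro in place of isopropyl on an aromatic carbon. Among the measured compounds shown here, no measured step covers this exchange directly. What the data show is that compound 1 and compound 2, which carry fluoro at that carbon and differ from compound 4 only on the sulfonyl sulfur, both give numbers far lower than compound 3, and that the sulfonyl variation itself was neutral. The expectation for compound 4 is therefore a large step downward, a 12-fold lower number from compound 3 to compound 4 (1.08 log units; beyond the scatter), bringing it close to compound 1 and compound 2. Compound 4 is estimated at 30 nM, with a range of 10 nM to 100 nM.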

Compound 4, half-maximal inhibitory concentration: 95 nM
Estimate against measurement, compound 4: 3.2-fold (0.50 log units) below, within the range that was stated.
By their numbers in this assay, from the lowest: compounds 1 and 2 (each within the scatter of the next); then compound 4; then compound 3.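

At this aromatic carbon, fluoro in place of isopropyl gives in this assay a 3.8-fold lower number from compound 3 to compound 4 (0.58 log units; beyond the scatter) and so is a real but modest change, which leaves part of the distance from compound 3 to compounds 1 and 2 with the group on the sulfonyl sulfur. That group is not freely variable: beside the neutral no change at the digits printed from compound 1 to compound 2 (within the scatter) stand a 4.1-fold higher number from compound 2 to compound 4 (0.62 log units; beyond the scatter) and a 4.1-fold higher number from compound 1 to compound 4 (0.62 log units; beyond the scatter), so methyl differs from both propyl and dimethylamino where those two do not differ from each other. Nothing available here bears on the reason for either change.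

Only fluoro and isopropyl are shown at this carbon, so hydrogen, chloro or methoxy there remain open. Isopropyl appears only with the methylsulfonyl group, so whether the fluoro step holds with propyl or dimethylamino on the sulfonyl sulfur also remains open.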